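Capping the hydroxy of compound 2 with 2-bromoethyl

A few compounds are considered here, and "the series" means these few. Any claim that something is new, unique, unknown or untested is made for them only; others in the source may bear on it.

Only compound 1 `COc1ccc(N(C)c2ccnc(Cl)n2)cc1Cl` and compound 2 `COc1ccc(N(C)c2ccnc(Cl)n2)cc1O` have been measured so far. In a functional assay on HepG2 cells (Homo sapiens) for antiproliferative activity, read by MTT assay, with a stated time of 48 h (on this read-out lower numbers stand for stronger inhibition and higher numbers for weaker inhibition), compound 1 gives 2630 nM and compound 2 gives 464 nM, so compound 2 holds the lower of the two numbers. The next compound is compound 3 `COc1ccc(N(C)c2ccnc(Cl)n2)cc1OCCBr`, and its difference from compound 2 is 2-bromoethyl in place of hydrogen on an oxygen on an aromatic ring. The hydroxy thus becomes 2-bromoethoxy.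

Within the data shown here, no measured compound carries a group on this oxygen, so the evidence is thin. Among the measured compounds shown here, the one measured step that bears on the change is a 5.7-fold lower number from compound 1 to compound 2 (0.75 log units; beyond the scatter), hydroxy in place of chloro on an aromatic carbon, and it lies beyond the scatter. It shows only that replacing the hydroxy of compound 2 with chloro gives a higher number, and a 2-bromoethyl group is a different change. A move to a higher number in this assay is therefore expected, of similar or smaller size than that step. The expected step is a 2.2-fold higher number from compound 2 to compound 3 (0.33 log units; beyond the scatter). The estimate for compound 3 is 1000 nM, with an expected range of 300 nM to 3500 nM.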

Compound 3, half-maximal inhibitory concentration: 7720 nM
Compound 3: the middle estimate sits 7.7-fold (0.89 log units) below what was measured; the measured number lies above the stated range.
By their numbers in this assay, from the lowest: compound 2; then compound 1; then compound 3.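

At this position, the oxygen does not take the 2-bromoethyl cap without loss: in this assay the change gives a 17-fold higher number from compound 2 to compound 3 (1.22 log units; beyond the scatter), and setting 2-bromoethoxy against chloro on the same aromatic carbon gives a 2.9-fold higher number from compound 1 to compound 3 (0.47 log units; beyond the scatter). The three groups seen at this place now stand in one order, with hydroxy giving the lowest number, then chloro, then 2-bromoethoxy, and each printed step lies beyond the scatter; compound 3 keeps the oxygen yet has the highest number, so among these three compounds an oxygen alone does not go with the low number of compound 2, and only the free hydroxy does. No measurement at hand speaks to the reason for this rise.

With a single capped compound, the contribution of capping the oxygen cannot be separated from that of the bromine at the end of the chain. Methoxy, ethoxy or 2-aminoethoxy at this place would show whether any group on this oxygen raises the number or only 2-bromoethyl does.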